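Methyl to Chloro on Compound 2

A few compounds are considered here, and "the series" means these few. Any claim that something is new, unique, unknown or untested is made for them only; others in the source may bear on it.

Among the compounds with values here, compound 2 `Cc1ccc(C(Nc2ccccn2)c2ccc3cccnc3c2O)cc1` gives 460 nM in an assay for inhibition of protein disulfide-isomerase (Homo sapiens), with a stated time of 1 h; on this read-out lower numbers stand for stronger inhibition and higher numbers for weaker inhibition; the only other number known, from compound 1 `Cc1ccc(C)c(C(Nc2ccccn2)c2ccc3cccnc3c2O)c1` at 730 nM, lies within the scatter of it, as the step of a 1.6-fold lower number from compound 1 to compound 2 (0.20 log units; within the scatter) shows. Compound 3 `Oc1c(C(Nc2ccccn2)c2ccc(Cl)cc2)ccc2cccnc12` differs from compound 2 by chloro in place of methyl on an aromatic carbon. Within the data shown here, no measured step exchanges a methyl for a chloro, and the single step known, between compound 1 and compound 2, swapped one methyl-bearing ring for another and stayed within the scatter. The expected step of a 1.1-fold lower number from compound 2 to compound 3 (0.04 log units; within the scatter) is therefore not beyond the scatter. Compound 3 is estimated at 420 nM, with a range from 150 nM to 1200 nM.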

Compound 3, half-maximal inhibitory concentration: 170 nM
Beside the measured number, compound 3's estimate is 2.5-fold (0.39 log units) above it; measured number inside the range.
By their numbers in this assay, from the lowest: compound 3; then compounds 2 and 1 (each within the scatter of the next).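

Chloro in place of methyl gives a 2.7-fold lower number from compound 2 to compound 3 (0.43 log units; beyond the scatter) and so is the first change on this ring to pass the scatter. In this assay the 4-chlorophenyl also stands clear of the 2,5-dimethylphenyl, with a 4.3-fold lower number from compound 1 to compound 3 (0.63 log units; beyond the scatter) and compound 3 lying beyond the scatter of both other compounds. Nothing at hand explains why the number falls with this swap.

As far as these compounds go, whether this drop is specific to chloro remains open, since fluoro, bromo or methoxy in that place could test it. From the compounds shown here alone, how an amine or a carboxylic acid there would read also stays unknown.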